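The source may hold more compounds than are shown below. What is called first, only, known or untested is meant among the compounds shown, and "the series" means these compounds.

Measured so far:
compound 1, `COc1ccccc1NC(=O)N[C@@H](C)c1ccccc1`: 95%
compound 2, `COc1cccc(NC(=O)N[C@H](C)c2ccccc2)c1`: 70%
compound 3, `CC(=O)c1ccccc1NC(=O)N[C@@H](C)c1ccccc1`: 96%

In an ADME assay on the whole organism with Oryza sativa as the target, tested at 10 uM (a lower number here means a stronger effect, a higher number a weaker effect of the compound at the concentration tested), compound 1 gives 95% and compound 3 gives 96%; the step is a number 1 percentage points higher from compound 1 to compound 3 (within the scatter), the change being (acetyl in place of methoxy on an aromatic carbon). Compound 2 has the same atoms as compound 1 joined differently; how the two cores differ is not broken down here. In this assay compound 2 gives 70%, which lies below the values of compound 1 and compound 3.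

Compound 4, `CC(=O)c1cccc(NC(=O)N[C@H](C)c2ccccc2)c1`, is not yet measured. It carries acetyl in place of methoxy on an aromatic carbon. This is the same kind of change as from compound 1 to compound 3, not the same one: there the entering group sits ortho to a large group, here meta to a large group. A small step is expected, a number 2 percentage points higher from compound 2 to compound 4 (within the scatter), because the earlier step of a number 1 percentage points higher from compound 1 to compound 3 (within the scatter) lies within the scatter. In this assay compound 4 is therefore estimated at 72%, expected between 55% and 90%.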

Compound 4, a percentage reported as activity, at one concentration (the size of the read-out at that concentration, not a potency): 73%
Compound 4: middle estimate off by 1 percentage points, on the low side, and the stated range covers the measured number.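

Working notes: in this assay, acetyl in place of methoxy on an aromatic carbon gives a number 3 percentage points higher from compound 2 to compound 4 (within the scatter). Across the two cores, the change shows no difference in the size of its step: the same change on two cores in this assay, a number 1 percentage points higher (within the scatter) from compound 1 to compound 3 and a number 3 percentage points higher (within the scatter) from compound 2 to compound 4, 2 percentage points apart, within the scatter of two such steps. Going by these compounds alone, this shows only that the change leaves the read-out within the scatter on these two cores; two pairs do not show that this holds on any other core, and they give no reason for the result.

On these data alone, it remains open whether a different group in the same place, such as an amine, a carboxylic acid or a longer chain, would move the read-out on either core. The compounds shown also leave open whether any such group would behave alike on both cores.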